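Methyl to Isopropyl: Extending a Substituent in Antiproliferative Screening

This account rests on a few compounds, and the source may have more. Where it says the series, first, only, none or still open, it means among the compounds named here.

Three measured compounds share one core and differ only in the group carried on the outer phenyl ring: compound 1 `CNC(=O)c1ccccc1Oc1nc(Nc2ccc(C(F)(F)F)cc2)ncc1Br`, compound 2 `CNC(=O)c1ccccc1Oc1nc(Nc2cccc(Br)c2)ncc1Br` and compound 3 `CNC(=O)c1ccccc1Oc1nc(Nc2cccc(C)c2)ncc1Br`. In a functional assay on MCF7 cells (Homo sapiens) for antiproliferative activity, read by MTT assay, with a stated time of 24 h (on this read-out lower numbers stand for stronger inhibition and higher numbers for weaker inhibition), compound 1 gives only a limit, > 50000 nM. Compound 2 gives 42500 nM in this assay. Compound 3 gives 16600 nM in this assay, the lowest of the two numbers reported, its nearest neighbour being compound 2 by the step of a 2.6-fold lower number from compound 2 to compound 3 (0.41 log units; beyond the scatter). For the measured compounds named here, a limit is all that is known for compound 1, so it sets no step against compound 3 (the limit of > 50000 nM in this assay, at which 1 of the 3 values shown sits).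

The next compound, compound 4 `CNC(=O)c1ccccc1Oc1nc(Nc2cccc(C(C)C)c2)ncc1Br`, differs from compound 3 in one place: isopropyl in place of methyl on an aromatic carbon. Going by the values given here, no measured step swaps methyl for isopropyl. Among the compounds with values here, the only step at that position is a 2.6-fold lower number from compound 2 to compound 3 (0.41 log units; beyond the scatter), a modest change from one small group to another, and it gives no direct reading on a larger alkyl group. Compound 4 is therefore expected to sit close to compound 3, with a step of a 1.4-fold lower number from compound 3 to compound 4 (0.14 log units; within the scatter) that may fall within the scatter, in either direction. The estimate for compound 4 in this assay is 12000 nM, with a range from 4000 nM to 40000 nM.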

Compound 4, half-maximal inhibitory concentration: 26500 nM
For compound 4 the middle estimate is 2.2-fold (0.34 log units) below the measured one; the range from low to high includes it.
By their numbers in this assay, from the lowest: compounds 3, 4 and 2 (each within the scatter of the next, the first and the last beyond it). At a limit, above all of these: compound 1.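

In this assay, going from 3-methylphenyl to 3-isopropylphenyl gives a 1.6-fold higher number from compound 3 to compound 4 (0.20 log units; within the scatter), so at this position the read-out does not separate methyl from isopropyl, although isopropyl brings 3 heavy atoms where methyl had 1. Isopropyl in place of bromo reads the same way, with a 1.6-fold lower number from compound 2 to compound 4 (0.21 log units; within the scatter), so compound 4 cannot be told apart from either neighbour, even though a 2.6-fold lower number from compound 2 to compound 3 (0.41 log units; beyond the scatter) remains the one step at this position that lies beyond the scatter. No measurement shown gives a cause for any of these steps.

The compounds shown leave open whether a group of another kind at this position, such as an amine, a carboxylic acid or a methoxy group, would shift the number beyond the scatter, and whether a longer chain or a tert-butyl group would stay level with methyl and isopropyl. Also open, going by these compounds, is what the outer phenyl ring would give with plain hydrogen in place of these groups, which would set bromo, methyl and isopropyl against a common reference.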